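This account rests on a few compounds, and the source may have more. Where it says the series, first, only, none or still open, it means among the compounds named here.

Working notes on the series. The shared core carries an anilino group on its pyrimidine; in a functional assay on MCF7 cells (Homo sapiens) for antiproliferative activity, read by MTT assay, with a stated time of 72 h (a higher number here means a weaker inhibitor of growth, a lower number a stronger inhibitor of growth), compound 1, `Cn1nc(-c2ccnc(Nc3ccc(Cl)cc3)n2)c2ccccc21`, gives 7830 nM, compound 2, `Cn1nc(-c2ccnc(Nc3cccc(Cl)c3)n2)c2ccccc21`, gives 5970 nM, and compound 3, `Cn1nc(-c2ccnc(Nc3ccc([N+](=O)[O-])cc3)n2)c2ccccc21`, gives 11800 nM. Compound 2 is the core of compound 4, `Cn1nc(-c2ccnc(Nc3cccc([N+](=O)[O-])c3)n2)c2ccccc21`, and differs from compound 1 by 3-chlorophenyl in place of 4-chlorophenyl on a nitrogen on an aromatic ring, a step of a 1.3-fold lower number from compound 1 to compound 2 (0.12 log units; within the scatter). Compound 4 arises from compound 2 by nitro in place of chloro on an aromatic carbon. The same change has been measured once, from compound 1 to compound 3, as nitro in place of chloro on an aromatic carbon, with a step of a 1.5-fold higher number from compound 1 to compound 3 (0.18 log units; within the scatter). The place differs: in compound 3 the nitro stands para to a large group, in compound 4 meta to a large group, so this is the same kind of change, not the same. Compound 4 is expected to move by a 1.5-fold higher number from compound 2 to compound 4 (0.18 log units; within the scatter), resting on the step from compound 1 to compound 3, within the scatter. Compound 4 is estimated at 9000 nM, from 4500 nM to 18000 nM.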

Compound 4, concentration for 50% growth inhibition: 580 nM
Beside the measured number, compound 4's estimate is 16-fold (1.19 log units) above it; measured number outside the range, below it.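

Nitro in place of chloro gives a 10-fold lower number from compound 2 to compound 4 (1.01 log units; beyond the scatter) in this assay, and this step does not match the earlier one: the same change on two cores in this assay, a 1.5-fold higher number (0.18 log units; within the scatter) from compound 1 to compound 3 and a 10-fold lower number (1.01 log units; beyond the scatter) from compound 2 to compound 4, 16-fold (1.19 log units) apart, beyond the scatter of two such steps

A step measured on one of these cores therefore cannot be carried to the other as it stands, since the change differs in both direction and size between the two pairs. Within the data shown here, with only two pairs, this does not show what sets the difference, nor how the change would behave on any further core.

On these data alone, it remains open whether the large step is particular to nitro, or whether another group meta to a large group, such as a nitrile or an amine, would give a value close to that of compound 4.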